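This account rests on a few compounds, and the source may have more. Where it says the series, first, only, none or still open, it means among the compounds named here.

Compound 1, `O=C(Nc1cccc(-n2cc(-c3ccncc3)c(-c3ccc(Cl)c(O)c3)n2)c1)Nc1cccc(C(F)(F)F)c1`, in a functional assay on DU-145 cells (Homo sapiens) for inhibition, read by sulforhodamine B assay, with a stated time of 48 h (a higher number here means that more compound is tolerated, a lower number that less compound is tolerated), compound 1 gives > 32500 nM, a limit of the assay.
Compound 2, `COc1cc(-c2nn(-c3cccc(NC(=O)Nc4cc(C(F)(F)F)cc(C(F)(F)F)c4)c3)cc2-c2ccncc2)ccc1Cl`, in this assay compound 2 gives 21100 nM.
Compound 3, `COc1cc(-c2nn(-c3cccc(NC(=O)Nc4cccc(C(F)(F)F)c4)c3)cc2-c2ccncc2)ccc1Cl`, in this assay compound 3 gives > 50000 nM, again a limit of the assay.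

Compound 2 is therefore the only one of the three with a number rather than a limit, and it is the starting point for compound 4, `O=C(Nc1cccc(-n2cc(-c3ccncc3)c(-c3ccc(Cl)c(O)c3)n2)c1)Nc1cc(C(F)(F)F)cc(C(F)(F)F)c1`, which has not yet been measured. Compound 4 differs from compound 2 by hydrogen in place of methyl on an oxygen on an aromatic ring; cut one bond further out, the change reads methoxy to hydroxy, 4-chloro-3-methoxyphenyl to 4-chloro-3-hydroxyphenyl. The same change at this oxygen, in the opposite direction, exists between compound 1 and compound 3, but a step that the two limits leave unreadable from compound 1 to compound 3 is unreadable because the limit of > 32500 nM in this assay, at which 1 of the 3 values shown sits, and the limit of > 50000 nM in this assay, at which 1 of the 3 values shown sits, bound both ends. The other measured step, an at least 2.3-fold higher number from compound 2 to compound 3 (0.37 log units; beyond the scatter), concerns the trifluoromethyl on the urea ring, which compound 4 keeps unchanged, so it does not bear on the present change. No readable step guides the expectation, and compound 4 is therefore expected to stay close to compound 2, with a 1.0-fold lower number from compound 2 to compound 4 (0.00 log units; within the scatter) lying within the scatter. Compound 4 is estimated at 21000 nM, with a range from 7000 nM to 63000 nM.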

Compound 4, concentration lethal to 50% of the cells: 17400 nM
Beside the measured number, compound 4's estimate is 1.2-fold (0.08 log units) above it; the measured number falls inside the stated range.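

In this assay, among these compounds, the change from methoxy to hydroxy on the 4-chloro-3-methoxyphenyl group can now be read for the first time, as a 1.2-fold lower number from compound 2 to compound 4 (0.08 log units; within the scatter), so on this core the exchange of methyl for hydrogen on the oxygen shows no difference beyond the scatter. Among the compounds shown here, the new compound also gives a first reading of the trifluoromethyl change on a hydroxy compound, an at least 1.8-fold lower number from compound 1 to compound 4 (0.27 log units; that floor lies within the scatter), and since that floor lies within the scatter, this step alone does not establish a difference. Taken with the earlier step, the trifluoromethyl change can now be compared on the methoxy and hydroxy compounds: the same change on two cores in this assay, an at least 2.3-fold higher number (0.37 log units; beyond the scatter) from compound 2 to compound 3 and an at least 1.8-fold higher number (0.27 log units; that floor lies within the scatter) from compound 4 to compound 1; the limit leaves it open whether they differ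

As far as these compounds go, the step between compound 1 and compound 3 cannot be read, as both values are limits of the assay, so it remains open whether methoxy and hydroxy also match on that core. From the compounds shown here alone, how a longer chain on this oxygen, or an amine in place of the hydroxy, would read in this assay also remains open.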